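The compounds below may be only part of what the source reports. "The series", "measured", "known", "first", "only" and "open" are said of these compounds alone.

Working notes on the series. Three compounds have numbers in a functional assay on KB cells (Homo sapiens) for antiproliferative activity, read by sulforhodamine B assay, with a stated time of 3 days; a lower number here means that less compound is needed, a higher number that more compound is needed for the effect: compound 1 (`CCCC1=C(OC)C(CCC)(CCC)C(=O)/C(=C(O)\C=C\c2ccc(I)cc2)C1=O`) gives 1.5 uM, compound 2 (`CCCC1=C(OCCC(C)C)C(CCC)(CCC)C(=O)/C(=C(O)\C=C\c2ccccc2)C1=O`) gives 10.6 uM, and compound 3 (`COC1=C(CC(C)C)C(=O)/C(=C(O)/C=C/c2ccccc2)C(=O)C1(CC(C)C)CC(C)C`) gives 7.9 uM. Compound 2 stands within the scatter of compound 3. Compound 1 lies beyond the scatter from compound 2, on the side where less compound is needed for the effect.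

Compound 4 (`CCCCOC1=C(CCC)C(=O)/C(=C(O)/C=C/c2ccccc2)C(=O)C1(CCC)CCC`) has not yet been measured in this assay. Going from compound 2 to compound 4, isopentyl becomes butyl: hydrogen in place of methyl on a saturated chain carbon bound to two saturated chain carbons. Going by the values given here, no two measured compounds differ in one place only, so the series offers no direct precedent for this change, and the expectation rests on thin ground.

No step beyond the scatter is expected in this assay. The reference point is compound 2 at 10.6 uM, with compound 3 at 7.9 uM close enough to fall within the scatter of it. The expected step, a 1.1-fold lower number from compound 2 to compound 4 (0.05 log units; within the scatter), is therefore small. The estimated value for compound 4 is 9.5 uM, with an expected range of 4.5 uM to 20 uM.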

Compound 4, concentration for half-maximal effect: 8 uM
The estimate for compound 4 lay 1.2-fold (0.07 log units) above the measured number; the range from low to high includes it.
By their numbers in this assay, from the lowest: compound 1; then compounds 3, 4 and 2 (each within the scatter of the next).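

Going by these compounds alone, compound 2 and compound 4 form the first pair that differs in one place only, so this change can now be read directly in this assay. Isopentyl to butyl, hydrogen in place of methyl on a saturated chain carbon bound to two saturated chain carbons, gives a 1.3-fold lower number from compound 2 to compound 4 (0.12 log units; within the scatter), so in this pair the methyl branch makes no readable difference to the antiproliferative number, and the two chains can be treated as interchangeable here. No measurement in hand bears on why the pair reads this way.

A single pair covers only a narrow change at this position, so it says nothing about groups that depart further from these two chains, such as a longer chain like octyl, a benzyl group, or a chain ending in an amine or a carboxylic acid. It also leaves open whether hydrogen in place of methyl would read the same on the other chains of the core, or with a different group on the phenyl ring of the side arm.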